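A few compounds are considered here, and "the series" means these few. Any claim that something is new, unique, unknown or untested is made for them only; others in the source may bear on it.

Measured so far:
compound 1 `Cc1cccnc1-c1cnc(C(=O)CCCCCCc2ccccc2)o1` — 15 nM
compound 2 `O=C(CCCCCCc1ccccc1)c1ncc(-c2cncnc2)o1` — 22 nM
compound 3 `CNC(=O)c1cnc(C(=O)CCCCCCc2ccccc2)o1` — 7 nM

In an assay (Rattus norvegicus) for inhibition of Fatty-acid amide hydrolase 1 (Homo sapiens) (a lower number here means a stronger inhibitor, a higher number a weaker inhibitor), compound 3 holds the lowest number of the three: a 2.1-fold lower number from compound 1 to compound 3 (0.33 log units; beyond the scatter) and a 3.1-fold lower number from compound 2 to compound 3 (0.50 log units; beyond the scatter) are both modest but beyond the scatter, while a 1.5-fold higher number from compound 1 to compound 2 (0.17 log units; within the scatter) is not. Compound 4 `O=C(CCCCCCc1ccccc1)c1ncc(C(=O)N2CCSCC2)o1` differs from compound 3 in one place: thiomorpholin-4-yl in place of methylamino on a carbonyl carbon. Among the compounds with values here, no measured step alters the substituent on this carbonyl carbon; the two steps into compound 3 only exchange an aromatic ring for the whole methylcarbamoyl group and give no direct precedent. The change is therefore expected to stay within the scatter, leaning if anything towards a slightly higher number, so a 1.7-fold higher number from compound 3 to compound 4 (0.23 log units; within the scatter) is the estimated step. Compound 4 is estimated at 12 nM in this assay, range 4 nM to 40 nM.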

Compound 4, inhibition constant: 10 nM
Beside the measured number, compound 4's estimate is 1.2-fold (0.08 log units) above it; the range from low to high includes it.
By their numbers in this assay, from the lowest: compounds 3, 4, 1 and 2 (each within the scatter of the next, the first and the last beyond it).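

On this carbonyl carbon, in this assay, a 1.4-fold higher number from compound 3 to compound 4 (0.15 log units; within the scatter) shows that methylamino can give way to the larger thiomorpholin-4-yl ring, which has no hydrogen-bond donor, without a change beyond the scatter. Against the aromatic groups, the (thiomorpholin-4-yl)carbonyl group gives a 2.2-fold lower number from compound 2 to compound 4 (0.34 log units; beyond the scatter) but only a 1.5-fold lower number from compound 1 to compound 4 (0.18 log units; within the scatter) so that just the first of these steps stands out. No measurement available here accounts for these steps.

Still open, going by these compounds, is whether morpholin-4-yl, with oxygen in place of the ring sulfur, or a carboxylic acid at this carbonyl carbon would stay within the scatter of compound 3.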